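The compounds below may be only part of what the source reports. "The series", "measured", "known", "first", "only" and "open" are said of these compounds alone.

Measured compounds in an ADME assay on NIH3T3 cells (Mus musculus) for cytotoxicity, read by CCK-8 assay, with a stated time of 24 h; a lower number here means a stronger inhibitor, a higher number a weaker inhibitor:

Compound 1 `C/C(=C\c1cc(-c2ccccc2)cs1)C(N)=O` gives > 50000 nM, which is a limit of the assay and not a number.

Compound 2 `C/C(=C\c1nc(-c2ccc(F)cc2)cs1)C(N)=O` gives > 50000 nM, again a limit rather than a number.

Compound 3 `C/C(=C\c1cccc(-c2ccc(C)cc2)c1)C(N)=O` gives > 50000 nM, also a limit.

Compound 1 thus stands at the same place as the other two measured compounds, at the upper limit of this assay; no ordering among the three can be drawn, since each value is only a limit (the limit of > 50000 nM in this assay, at which 3 of the 3 values shown sit). Among the measured compounds shown here, no pair among the measured compounds differs in a single place, so no measured step is available for the series.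

Compound 4 `C/C(=C\c1cc(-c2ccc([N+](=O)[O-])cc2)cs1)C(N)=O` is not yet measured. It differs from compound 1 by nitro in place of hydrogen on an aromatic carbon. With every measured value sitting at the limit (the limit of > 50000 nM in this assay, at which 3 of the 3 values shown sit), nothing in the numbers points to a direction for this change, and no step beyond the usual scatter is expected; the estimated step that the limit leaves unreadable from compound 1 to compound 4 is correspondingly small. Compound 4 is expected to give about 60000 nM in this assay, within a range of 20000 nM to 200000 nM, most probably reported again only as a limit.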

Compound 4, half-maximal inhibitory concentration: > 50000 nM
Compound 4: a limit, no number; the forecaster's own chance of this, stated with the estimate: 85%; the middle value does not contradict the limit.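

Among the compounds shown here, compound 1 and compound 4 both sit at a limit of the assay and not at a number, so no step between them can be read: the limit of > 50000 nM in this assay, at which 4 of the 4 values shown sit.

The compounds shown leave open what structural change, if any, would give a measurable value in this assay.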